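A few compounds are considered here, and "the series" means these few. Any claim that something is new, unique, unknown or untested is made for them only; others in the source may bear on it.

Of the compounds shown here, three with a shared core have been measured in an assay on isolated protein for inhibition of cathepsin S (Homo sapiens); a lower number here means a stronger inhibitor, a higher number a weaker inhibitor. Compound 1 `CS(=O)(=O)CC[C@H](CNc1ccc(OC(F)(F)F)cc1)NC(=O)[C@@H](CC(=O)N1CCOCC1)CC1CCCCC1` gives 69 nM, compound 2 `C[C@@H](CNc1ccc(OC(F)(F)F)cc1)NC(=O)[C@@H](CC(=O)N1CCOCC1)CC(C)(C)C` gives 408 nM, and compound 3 `CC(C)[C@@H](CNc1ccc(OC(F)(F)F)cc1)NC(=O)[C@H](CCCc1ccccc1)CC(=O)N1CCOCC1` gives 14 nM. Compound 2 thus has the highest number of the three, and its distance to both compound 1 and compound 3 lies beyond the usual scatter, so it is the least potent of the set. Compound 4 `C[C@@H](CNc1ccc(OC(F)(F)F)cc1)NC(=O)[C@H](CCC(C)(C)C)CC(=O)N1CCOCC1` differs from compound 2 by one change: neopentyl in place of tert-butyl on a saturated chain carbon, two bonds along the chain from a carbonyl carbon. Compound 1 carries a cyclohexylmethyl group at that same place, and its value of 69 nM suggests that a longer chain there goes with a lower number. The step of a 2.0-fold lower number from compound 2 to compound 4 (0.31 log units; beyond the scatter) is therefore expected to be a modest gain. For compound 4 an inhibition constant of about 200 nM is estimated, within a range from 70 nM to 600 nM.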

Compound 4, inhibition constant: 70 nM
The estimate for compound 4 lay 2.9-fold (0.46 log units) above the measured number, within the range that was stated.
By their numbers in this assay, from the lowest: compound 3; then compounds 1 and 4 (each within the scatter of the next); then compound 2.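

In this assay, within the data shown here, neopentyl in place of tert-butyl on a saturated chain carbon, two bonds along the chain from a carbonyl carbon, gives a 5.8-fold lower number from compound 2 to compound 4 (0.77 log units; beyond the scatter) and is the first change in this set that can be read at a single place. The number at this position therefore responds to one added carbon, with no ring and no hydrogen-bond donor or acceptor entering. Nothing available explains the size of this step.

From the compounds shown here alone, whether a longer chain would lower the number further remains open. So does the effect of an amine or a carboxylic acid at the end of this chain.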